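A few compounds are considered here, and "the series" means these few. Any claim that something is new, unique, unknown or untested is made for them only; others in the source may bear on it.

Measured so far:
- compound 1, `CC(C)(C)[C@@H](O)C(=O)N1[C@@H]2C[C@@H]2C[C@H]1C(=O)NCc1cc(Cl)ccc1-n1cnnn1`: 54 mL.min-1.g-1
- compound 2, `O=C(NCc1cc(Cl)ccc1-n1cnnn1)[C@@H]1[C@H]2C[C@H]2CN1C(=O)[C@H](O)c1ccccc1`: 61 mL.min-1.g-1
- compound 3, `CCCC[C@@H](O)C(=O)N1C[C@H]2C[C@H]2[C@H]1C(=O)NCc1cc(Cl)ccc1-n1cnnn1`: 32 mL.min-1.g-1

All three share one core and differ only in the group on the saturated chain carbon bound to the carbonyl carbon and an oxygen on a saturated carbon. In an ADME assay on liver for metabolic stability, with Liver microsome (Homo sapiens) as the target, read by LC-MS, using microsomes (a lower number here means slower removal, a higher number faster removal of the compound), compound 1 gives 54 mL.min-1.g-1; compound 2 gives 61 mL.min-1.g-1 and compound 3 gives 32 mL.min-1.g-1 in this assay. The number for compound 1 lies closest to that of compound 2, and furthest from that of compound 3, yet both gaps fall within the scatter of repeated measurements, so the three compounds cannot be separated on the numbers shown.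

Compound 4, `O=C(NCc1cc(Cl)ccc1-n1cnnn1)[C@@H]1C[C@H]2C[C@H]2N1C(=O)[C@H](O)CC1CC1`, is not yet measured in this assay. It differs from compound 1 by cyclopropylmethyl in place of tert-butyl on a saturated chain carbon bound to a carbonyl carbon and an oxygen on a saturated carbon. Nothing comparable has been measured within the series, and since the tert-butyl, phenyl and butyl groups of compounds 1, 2 and 3 sit within the scatter of one another, no step beyond the scatter is expected in this assay from a fourth saturated carbon group of the same size. The step of a 1.2-fold lower number from compound 1 to compound 4 (0.08 log units; within the scatter) is therefore estimated to stay within the scatter. For compound 4 the expected value in this assay is 45 mL.min-1.g-1, with a range from 22 mL.min-1.g-1 to 90 mL.min-1.g-1.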

Compound 4, intrinsic clearance in microsomes: 25 mL.min-1.g-1
For compound 4 the middle estimate is 1.8-fold (0.26 log units) above the measured one; the measured number falls inside the stated range.
By their numbers in this assay, from the lowest: compounds 4, 3, 1 and 2 (each within the scatter of the next, the first and the last beyond it).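

Among the compounds shown here, at the saturated chain carbon bound to a carbonyl carbon and an oxygen on a saturated carbon, the exchange of tert-butyl for cyclopropylmethyl gives the first step beyond the scatter in this assay: a 2.2-fold lower number from compound 1 to compound 4 (0.33 log units; beyond the scatter), a modest change. Both groups have the same heavy-atom count, all carbon, and neither has a hydrogen-bond donor, a hydrogen-bond acceptor or a net charge, so the counts separate them only by the three-membered ring, and an equal heavy-atom count at this position does not ensure an equal number. The data shown contain no independent measurement that accounts for this step.

This single pair leaves open whether the three-membered ring itself goes with the lower number, or whether an open isobutyl chain or a cyclobutyl group at the same place on the core of compound 1 would give a similar step in this assay. On these data alone, the response of this position to an amine or a carboxylic acid also remains open, as does whether the step carries over to the other arrangements of the core seen.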